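A few compounds are considered here, and "the series" means these few. Any claim that something is new, unique, unknown or untested is made for them only; others in the source may bear on it.

Compound 3 `CC(C)c1cccc(C(C)C)c1NC(=O)Nc1nc2ccccc2n1-c1c(Cl)cccc1Cl` holds the lowest of the three numbers measured in an assay on isolated protein for displacement of a labelled ligand from acyl-CoA:cholesterol acyltransferase (Oryctolagus cuniculus); on this read-out higher numbers stand for weaker inhibition and lower numbers for stronger inhibition: compound 3 gives 11 nM. Compound 1 `CC(C)c1cccc(C(C)C)c1NC(=O)Nc1nc2ccccc2n1-c1ccccc1Br` gives 22 nM in this assay, and compound 2 `CC(C)c1cccc(C(C)C)c1NC(=O)Nc1nc2ccccc2n1-c1ccccc1C(F)(F)F` gives 72 nM. The step of a 2.0-fold lower number from compound 1 to compound 3 (0.30 log units; within the scatter) lies within the scatter, whereas a 6.5-fold lower number from compound 2 to compound 3 (0.82 log units; beyond the scatter) and a 3.3-fold higher number from compound 1 to compound 2 (0.51 log units; beyond the scatter) lie beyond it, so the group on the aromatic nitrogen does move the number. Compound 4 `CC(C)c1cccc(C(C)C)c1NC(=O)Nc1nc2ccccc2n1-c1ccccc1O` differs from compound 3 in exactly that place: 2-hydroxyphenyl in place of 2,6-dichlorophenyl on an aromatic nitrogen. Within the data shown here, none of the measured steps exchanges halogens for a hydroxyl, so the evidence bears only loosely on this change; the two steps that end at compound 3 are a beyond-scatter step from compound 2 and a within-scatter step from compound 1, and a group carrying one hydrogen-bond donor and one hydrogen-bond acceptor is untested in this set. The expected step is a 4.5-fold higher number from compound 3 to compound 4 (0.66 log units; beyond the scatter), a modest rise in the number. Compound 4 is therefore estimated at 50 nM in this assay, with a range from 15 nM to 200 nM.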

Compound 4, half-maximal inhibitory concentration: 200 nM
Compound 4: the middle estimate sits 4.0-fold (0.60 log units) below what was measured; the range from low to high includes it.
By their numbers in this assay, from the lowest: compounds 3 and 1 (each within the scatter of the next); then compound 2; then compound 4.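

In this assay the 2-hydroxyphenyl group gives the largest change seen at this aromatic nitrogen, with an 18-fold higher number from compound 3 to compound 4 (1.26 log units; beyond the scatter) as the step from the 2,6-dichlorophenyl group. Among these compounds, the position is therefore more sensitive than the earlier compounds showed, and replacing a single group on the phenyl ring also raises the number beyond the scatter, with a 9.1-fold higher number from compound 1 to compound 4 (0.96 log units; beyond the scatter) for hydroxy in place of bromo and a 2.8-fold higher number from compound 2 to compound 4 (0.44 log units; beyond the scatter) for hydroxy in place of trifluoromethyl. Nothing available explains why the hydroxy compound gives the highest number of the four.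

Methoxy or an amine in place of the hydroxy would test whether the rise is specific to the hydroxy group. The compounds shown also leave open how much of an 18-fold higher number from compound 3 to compound 4 (1.26 log units; beyond the scatter) comes from losing the second chlorine rather than from adding hydroxy.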